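A few compounds are considered here, and "the series" means these few. Any claim that something is new, unique, unknown or untested is made for them only; others in the source may bear on it.

In a functional assay on HOP-92 cells (Homo sapiens) for cytotoxicity, read by sulforhodamine B assay, with a stated time of 48 h (on this read-out lower numbers stand for stronger inhibition of growth and higher numbers for weaker inhibition of growth), compound 1 `ClCc1cccc(Cn2cnc3c(Cl)ncnc32)c1` gives 2450 nM, and compound 2 `ClCc1cccc(Cn2cnc3c(Cl)nc(Cl)nc32)c1` gives 1820 nM. The two differ by chloro in place of hydrogen on an aromatic carbon, a change that made a 1.3-fold lower number from compound 1 to compound 2 (0.13 log units; within the scatter). Compound 3 `ClCc1ccccc1Cn1cnc2ncnc(Cl)c21` gives 4360 nM in this assay; the difference between its core and the core of compound 1 is not broken down here. Compound 4 `ClCc1ccccc1Cn1cnc2nc(Cl)nc(Cl)c21` has not yet been measured in this assay. For the measured compounds named here, it differs from compound 3 by chloro in place of hydrogen on an aromatic carbon, the same change as the one from compound 1 to compound 2. For compound 4 the expected step is a 1.3-fold lower number from compound 3 to compound 4 (0.12 log units; within the scatter), which rests on the earlier 1.3-fold lower number from compound 1 to compound 2 (0.13 log units; within the scatter). Compound 4 is therefore estimated to give about 3300 nM in this assay, with an expected range from 1600 nM to 6800 nM.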

Compound 4, concentration for 50% growth inhibition: 1140 nM
Compound 4: middle estimate off by 2.9-fold (0.46 log units), on the high side, outside the stated range (below it).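

In this assay, chloro in place of hydrogen on an aromatic carbon between two ring nitrogen atoms gives a 3.8-fold lower number from compound 3 to compound 4 (0.58 log units; beyond the scatter). The change does not carry over from one core to the other at a single size: the same change on two cores in this assay, a 1.3-fold lower number (0.13 log units; within the scatter) from compound 1 to compound 2 and a 3.8-fold lower number (0.58 log units; beyond the scatter) from compound 3 to compound 4, 2.8-fold (0.45 log units) apart, beyond the scatter of two such steps. The step on the core of compound 1 therefore did not foretell the size of the step on the core of compound 3, but two pairs do not show what in the cores sets this gap, or how the change would behave on a third core.

The compounds shown carry only chloro or hydrogen at this ring carbon, so an amine or a methoxy group there remains open. Also open, as far as these compounds go, is how a hydroxymethyl group in place of the chloromethyl group would read in this assay.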